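Bromine to isobutyl on the pyridine ether series

The compounds below may be only part of what the source reports. "The series", "measured", "known", "first", "only" and "open" are said of these compounds alone.

Compound 2 `CN1CCC[C@H]1COc1cncc(Br)c1` gives 0.27 nM in an assay on membranes from brain for displacement of a labelled ligand from Neuronal acetylcholine receptor; alpha4/beta2 (Rattus norvegicus) (a higher number here means a weaker inhibitor, a lower number a stronger inhibitor), the highest of the two numbers in hand; compound 1 `CN1CCC[C@H]1COc1cccnc1` gives 0.15 nM, and the step of a 1.8-fold higher number from compound 1 to compound 2 (0.26 log units; within the scatter) lies within the scatter. Compound 3 `CC(C)Cc1cncc(OC[C@@H]2CCCN2C)c1` differs from compound 2 by isobutyl in place of bromo on an aromatic carbon. Among the measured compounds shown here, the only measured step, from hydrogen to bromo, was small, and no step with an alkyl group exists, so compound 3 is expected to give a somewhat higher number, a 3.0-fold higher number from compound 2 to compound 3 (0.47 log units; beyond the scatter), without firm support. The estimate for compound 3 is 0.8 nM, within 0.15 nM to 5 nM.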

Compound 3, inhibition constant: 0.21 nM
For compound 3 the middle estimate is 3.8-fold (0.58 log units) above the measured one; the range from low to high includes it.
By their numbers in this assay, from the lowest: compounds 1, 3 and 2 (each within the scatter of the next).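

Isobutyl on this aromatic carbon, two atoms from the ring nitrogen, leaves the number in this assay essentially unchanged: the exchange for bromo gives a 1.3-fold lower number from compound 2 to compound 3 (0.11 log units; within the scatter) and the exchange for hydrogen gives a 1.4-fold higher number from compound 1 to compound 3 (0.15 log units; within the scatter) as well. This position, so far tested only with bromo, therefore also carries an alkyl group of 4 carbon atoms with no step beyond the scatter. Nothing available explains this result.

The compounds shown leave open whether a longer chain, an amine or a carboxylic acid at this position would also stay within the scatter.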